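Methoxy in Place of Hydrogen: From Compound 1 to Compound 4

A few compounds are considered here, and "the series" means these few. Any claim that something is new, unique, unknown or untested is made for them only; others in the source may bear on it.

Compound 1 `O=C/C=C/c1ccccc1OCc1ccccc1` is the starting point. Within the data shown here, in a functional assay on cells (Neutrophil, Rattus norvegicus, strain Sprague-Dawley) for inhibition (a higher number here means a weaker inhibitor, a lower number a stronger inhibitor), compound 1 gives 6400 nM, the highest of the three numbers measured so far, though the other two sit close by. Compound 2 `O=C/C=C/c1ccccc1OCc1ccccc1Cl` gives 4400 nM, and compound 3 `O=C/C=C/c1ccccc1OCc1cccc(Cl)c1` gives 5900 nM. Both steps away from compound 1 stay within the scatter: a 1.5-fold lower number from compound 1 to compound 2 (0.16 log units; within the scatter) and a 1.1-fold lower number from compound 1 to compound 3 (0.04 log units; within the scatter). Each of these puts a chloro group in place of a hydrogen on an aromatic carbon, so a single added aromatic substituent has so far left this assay essentially unchanged.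

Compound 4 `COc1ccc(COc2ccccc2/C=C/C=O)cc1` differs from compound 1 by methoxy in place of hydrogen on an aromatic carbon. No methoxy group has been tried before, so the two chloro steps bear on it only loosely, as examples of one small group added to the same ring. Because a 1.5-fold lower number from compound 1 to compound 2 (0.16 log units; within the scatter) and a 1.1-fold lower number from compound 1 to compound 3 (0.04 log units; within the scatter) were both within the scatter, no step beyond the scatter is expected here in either direction. The estimate for compound 4 is therefore 5500 nM, with a range from 2500 nM to 12000 nM, which amounts to an expected step of a 1.2-fold lower number from compound 1 to compound 4 (0.07 log units; within the scatter).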

Compound 4, half-maximal inhibitory concentration: 3800 nM
The estimate for compound 4 lay 1.4-fold (0.16 log units) above the measured number, within the range that was stated.
By their numbers in this assay, from the lowest: compounds 4, 2, 3 and 1 (each within the scatter of the next).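

In this assay, methoxy on an aromatic carbon para to a large group gives a 1.7-fold lower number from compound 1 to compound 4 (0.23 log units; within the scatter) and so stays within the scatter. Among these compounds, this is the first group that contains oxygen and counts a hydrogen-bond acceptor, and it joins the two chloro changes in leaving the number without a step beyond the scatter. No accompanying measurement offers an explanation for this result.

On these data alone, it remains open whether an amine or a carboxylic acid at this same position would produce a step beyond the scatter, or whether a longer chain in place of methoxy would do so. The compounds shown also leave open how methoxy would behave on other carbons of this ring, since this is the only position where it appears.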